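Swapping the urea aryl group on a biaryl sulfonamide urea

The compounds below may be only part of what the source reports. "The series", "measured", "known", "first", "only" and "open" are said of these compounds alone.

Compound 3, `O=C(NCCNS(=O)(=O)c1ccc(-c2ccccc2Oc2ccc([N+](=O)[O-])c([N+](=O)[O-])c2)s1)Nc1cc(Cl)cc(Cl)c1`, is the compound with the lowest number among those measured here. In a functional assay on HL-60 cells (Homo sapiens) for inhibition, read by CCK-8 assay, with a stated time of 48 h (a lower number here means a stronger inhibitor, a higher number a weaker inhibitor), compound 3 gives 2300 nM. Going by the values given here, its nearest neighbour is compound 2, `O=C(NCCNS(=O)(=O)c1ccc(-c2ccccc2OCc2ccccc2)s1)Nc1cc(Cl)cc(Cl)c1`, which in this assay gives 11700 nM; the step of a 5.1-fold lower number from compound 2 to compound 3 (0.71 log units; beyond the scatter) is the only change between measured compounds that can be followed. Compound 1, `Nc1ccc(Oc2ccccc2-c2ccc(S(=O)(=O)NCCNC(=O)Nc3ccc(Cl)cc3)s2)cc1`, carries a 4-chlorophenyl group on the urea and an aminophenyl ether, and in this assay it reaches only a limit of > 50000 nM. Among the compounds with values here, that limit, (the limit of > 50000 nM in this assay, at which 1 of the 3 values shown sits), is the sole place where a 4-chlorophenyl urea appears, but compound 1 differs from compound 3 in two places, so no single step can be drawn from it.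

Compound 4, `O=C(NCCNS(=O)(=O)c1ccc(-c2ccccc2Oc2ccc([N+](=O)[O-])c([N+](=O)[O-])c2)s1)Nc1ccc(Cl)cc1`, differs from compound 3 in one place: 4-chlorophenyl in place of 3,5-dichlorophenyl on an amide-type nitrogen. Within the data shown here, none of the measured steps touches the urea nitrogen, so the size of this step in this assay is unknown, and no step beyond the scatter is expected in either direction. Compound 4 is therefore estimated at 4000 nM, within 1500 nM to 15000 nM, corresponding to an expected step of a 1.7-fold higher number from compound 3 to compound 4 (0.24 log units; within the scatter).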

Compound 4, half-maximal inhibitory concentration: 8100 nM
Estimate against measurement, compound 4: 2.0-fold (0.31 log units) below; measured number inside the range.
By their numbers in this assay, from the lowest: compound 3; then compounds 4 and 2 (each within the scatter of the next). At a limit, above all of these: compound 1.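

Going by these compounds alone, until now no step touched the urea nitrogen, and here the aryl group on this amide-type nitrogen proves to matter: in this assay the change from 3,5-dichlorophenyl to 4-chlorophenyl gives a 3.5-fold higher number from compound 3 to compound 4 (0.55 log units; beyond the scatter) and so lies beyond the scatter. The result also adds a second readable change on the oxygen on an aromatic ring, which had been followed only from benzyl to 3,4-dinitrophenyl: 3,4-dinitrophenyl in place of 4-aminophenyl gives an at least 6.1-fold lower number from compound 1 to compound 4 (0.79 log units; beyond the scatter) on the same 4-chlorophenyl urea. Compound 1 stands at a limit and not at a number, so this second step fixes only a minimum size: the limit of > 50000 nM in this assay, at which 1 of the 4 values shown sits.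

Within the data shown here, whether the urea step keeps its size with other groups on the oxygen stays open, for the pair of 3,5-dichlorophenyl and 4-chlorophenyl is seen only with 3,4-dinitrophenyl. Going by these compounds, how much each chlorine contributes also stays open, as does how a 3-chlorophenyl or a 3,5-difluorophenyl group on the urea would compare.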